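The source may hold more compounds than are shown below. What is called first, only, known or untested is meant among the compounds shown, and "the series" means these compounds.

Compound 1, `O=[N+]([O-])c1ccc2[nH]c(-c3ccc(Cl)c(Br)c3)nc2c1`: in a functional assay for antagonist activity at Neuropeptides B/W receptor type 1 (Homo sapiens), read by cAMP accumulation (a lower number here means a stronger inhibitor, a higher number a weaker inhibitor), compound 1 gives > 31600 nM, which is a limit of the assay.
Compound 2, `O=[N+]([O-])c1ccc2[nH]c(-c3ccc(C(F)(F)F)cc3)nc2c1`: in this assay compound 2 gives > 31600 nM, again a limit of the assay rather than a number.
Compound 3, `O=[N+]([O-])c1ccc2nc(-c3ccccc3Cl)[nH]c2c1`: in this assay compound 3 gives 10700 nM.

Compound 2 therefore stands at the edge of what this assay can report; two of the three readings sit at the limit of > 31600 nM in this assay, at which 2 of the 3 values shown sit, and only compound 3 has a number of its own. Compound 4, `CC(C)(C)c1ccc(-c2nc3cc([N+](=O)[O-])ccc3[nH]2)cc1`, differs from compound 2 by tert-butyl in place of trifluoromethyl on an aromatic carbon. Among the compounds with values here, no step between two measured compounds is available here, so the three readings give no guide to how an exchange at that position shifts the readout. The step expected in this assay is accordingly a small one, likely none beyond the usual scatter, with a real chance that compound 4 also returns only a limit. Compound 4 is expected to give about 30000 nM, within a range of 8000 nM to 100000 nM. That estimate corresponds to an at least 1.0-fold lower number from compound 2 to compound 4 (0.02 log units; that floor lies within the scatter), which is expected to be no more than the scatter of the method.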

Compound 4, half-maximal inhibitory concentration: 3180 nM
The estimate for compound 4 lay 9.4-fold (0.97 log units) above the measured number; the whole stated range lies above it.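

In this assay, within the data shown here, tert-butyl in place of trifluoromethyl on an aromatic carbon, para to a large group, gives an at least 9.9-fold lower number from compound 2 to compound 4 (0.99 log units; beyond the scatter), the first step that can be read here, and it shows that the readout at this position depends on which group sits there. The two groups have the same heavy-atom count and neither has a ring, so the step comes with an exchange of fluorine atoms for carbon atoms, although the compounds shown do not explain it. The size of the step is only a floor because compound 2 gives a limit of the assay and not a number: the limit of > 31600 nM in this assay, at which 2 of the 4 values shown sit.

From the compounds shown here alone, whether a longer alkyl chain, a methoxy group or an amine at this position would lower the number further remains open. The nitro group is common to all the compounds shown, so what an exchange for a nitrile or an amine there would do also remains open.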